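Trading the Benzamido Group for a Short Isobutoxy Chain

A few compounds are considered here, and "the series" means these few. Any claim that something is new, unique, unknown or untested is made for them only; others in the source may bear on it.

Of the compounds shown here, three sharing one core have been tested in a functional assay on HEK293 cells for agonist activity at G-protein coupled receptor 39 (Homo sapiens), read by scintillation proximity assay and inositol phosphate accumulation, with a stated time of 75 min; a lower number here means that less compound is needed, a higher number that more compound is needed for the effect. Compound 1 `Cc1nn(-c2ncnc3nc[nH]c23)c2c1C(C(=O)NCc1ccccc1)CC(=O)N2` gives 2930 nM, compound 2 `Cc1nn(-c2ncnc3nc[nH]c23)c2c1C(OCc1ccc(C(C)C)cc1)CC(=O)N2` gives 1690 nM, and compound 3 `Cc1nn(-c2ncnc3nc[nH]c23)c2c1C(NC(=O)c1ccccc1)CC(=O)N2` gives 158 nM, the lowest of the three. Compound 4 `Cc1nn(-c2ncnc3nc[nH]c23)c2c1C(OCC(C)C)CC(=O)N2` differs from compound 3 by isobutoxy in place of benzamido on a saturated ring carbon. For the measured compounds named here, no measured step covers this exact swap. Going by the values given here, the only single-point step on record, a 19-fold lower number from compound 1 to compound 3 (1.27 log units; beyond the scatter), shows that the benzamido group accompanies a large gain, and compound 2, which also carries an oxygen-linked group at that carbon, sits well above compound 3. With the benzamido group gone, a clearly higher number is expected: compound 4 is estimated at 2500 nM, between 800 nM and 8000 nM, a step of a 16-fold higher number from compound 3 to compound 4 (1.20 log units; beyond the scatter).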

Compound 4, half-maximal effective concentration: 111 nM
Compound 4: middle estimate off by 23-fold (1.35 log units), on the high side, and the stated range ends above it.
By their numbers in this assay, from the lowest: compounds 4 and 3 (each within the scatter of the next); then compounds 2 and 1 (each within the scatter of the next).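

Isobutoxy in place of benzamido leaves the number within the scatter (a 1.4-fold lower number from compound 3 to compound 4 (0.15 log units; within the scatter)), so neither a six-membered aromatic ring nor a hydrogen-bond donor on this saturated ring carbon is required for a low number. The aromatic ring can even work against it among the oxygen-linked groups: isopropyl in place of 4-isopropylphenyl gives a large step (a 15-fold lower number from compound 2 to compound 4 (1.18 log units; beyond the scatter)), and isobutoxy in place of benzylcarbamoyl gives another (a 26-fold lower number from compound 1 to compound 4 (1.42 log units; beyond the scatter)). No data are available that explain these numbers. From the compounds shown here alone, whether an amine or a longer chain on this carbon would keep the number this low remains open.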